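A few compounds are considered here, and "the series" means these few. Any claim that something is new, unique, unknown or untested is made for them only; others in the source may bear on it.

Of the compounds shown here, three sharing one core have been measured in a functional assay on U-87MG ATCC cells for antiproliferative activity against U-87 MG (Homo sapiens), read by MTT assay, with a stated time of 48 h; a higher number here means a weaker inhibitor, a lower number a stronger inhibitor. Compound 1 (`COc1ccc(-c2nc(C)c(C(=O)CSc3nc(-c4cccc(OC)c4)c(C#N)c(=O)[nH]3)s2)cc1`) gives 15300 nM, compound 2 (`COc1ccc(-c2nc(C)c(C(=O)CSc3nc(-c4ccc(OC)c(OC)c4)c(C#N)c(=O)[nH]3)s2)cc1`) gives 12500 nM and compound 3 (`COc1ccc(-c2nc(SCC(=O)c3sc(-c4ccccc4)nc3C)[nH]c(=O)c2C#N)cc1OC`) gives 15300 nM. Compound 2 thus stands level with the other two, all three numbers lying within the scatter of one another. Compound 4 (`COc1ccc(-c2nc(C)c(C(=O)CSc3nc(-c4ccc(Cl)c(Cl)c4)c(C#N)c(=O)[nH]3)s2)cc1`) has 3,4-dichlorophenyl in place of the 3,4-dimethoxyphenyl of compound 2 on an aromatic carbon, next to the ring nitrogen and ortho to a cyano group: 3,4-dichlorophenyl in place of 3,4-dimethoxyphenyl on an aromatic carbon. Within the data shown here, two measured steps bear on this change. Adding a methoxy to the same aromatic group gave a 1.2-fold lower number from compound 1 to compound 2 (0.09 log units; within the scatter), and removing a methoxy from another aromatic group gave a 1.2-fold higher number from compound 2 to compound 3 (0.09 log units; within the scatter). Neither step involves chlorine, so the guide is thin, yet starting from compound 2 at 12500 nM, no step beyond the scatter is expected in this assay. The estimated step is a 1.3-fold lower number from compound 2 to compound 4 (0.10 log units; within the scatter). Compound 4 is estimated at 10000 nM, with an expected range of 3500 nM to 25000 nM.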

Compound 4, half-maximal inhibitory concentration: 68500 nM
Compound 4: middle estimate off by 6.9-fold (0.84 log units), on the low side; the whole stated range lies below it.
By their numbers in this assay, from the lowest: compounds 2, 1 and 3 (each within the scatter of the next); then compound 4.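

Among these compounds, at this position, next to the ring nitrogen and ortho to a cyano group, the one earlier change, adding a methoxy, gave a 1.2-fold lower number from compound 1 to compound 2 (0.09 log units; within the scatter) in this assay and so showed no sensitivity to the aryl substituents. Replacing methoxy with chlorine does register: 3,4-dichlorophenyl in place of 3,4-dimethoxyphenyl gave a 5.5-fold higher number from compound 2 to compound 4 (0.74 log units; beyond the scatter) and 3,4-dichlorophenyl in place of 3-methoxyphenyl gave a 4.5-fold higher number from compound 1 to compound 4 (0.65 log units; beyond the scatter) in the same direction, so the position is not indifferent to what the phenyl ring carries. No measurement at hand gives a reason for this loss.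

Going by these compounds, the two chlorines enter together, so it remains open whether a phenyl carrying a single chlorine would read like compound 4 or like the methoxy compounds. On these data alone, how a phenyl carrying a hydroxyl or an amine would read here also remains open.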